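A few compounds are considered here, and "the series" means these few. Any claim that something is new, unique, unknown or untested is made for them only; others in the source may bear on it.

For the measured compounds named here, in a functional assay on C6 cells (Rattus norvegicus) for inhibition, read by sulforhodamine B assay, with a stated time of 72 h (a higher number here means that more compound is needed for the effect, a lower number that less compound is needed), compound 1 `CC(C)(C)c1ccc(C(=O)/C=C/c2ccc([N+](=O)[O-])o2)cc1` gives 28600 nM and compound 2 `O=C(/C=C/c1ccc([N+](=O)[O-])o1)c1ccc(N2CCCC2)cc1` gives 16400 nM, so compound 1 stands within the scatter of the only other measured compound. Compound 3 `CC(C)(C)c1ccc(C(=O)/C=C/c2ccco2)cc1` carries one change from compound 1: hydrogen in place of nitro on an aromatic carbon. Going by the values given here, the single measured step, a 1.7-fold lower number from compound 1 to compound 2 (0.24 log units; within the scatter), concerns a different place and lies within the scatter, so no measured step tests this change. Only a small move towards a higher number is therefore expected in this assay, with wide uncertainty. The estimate is a 1.4-fold higher number from compound 1 to compound 3 (0.15 log units; within the scatter). Compound 3 is expected at 40000 nM, with an estimated range of 14000 nM to 110000 nM.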

Compound 3, half-maximal effective concentration: 18500 nM
The estimate for compound 3 lay 2.2-fold (0.33 log units) above the measured number; the range from low to high includes it.
By their numbers in this assay, from the lowest: compounds 2, 3 and 1 (each within the scatter of the next).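

In this assay, for the compounds shown here, hydrogen in place of nitro next to the ring oxygen gives a 1.5-fold lower number from compound 1 to compound 3 (0.19 log units; within the scatter) with the tert-butyl group kept, the first measured step at this position. At this place, then, the nitro group is not shown to be needed for the read-out in this assay. Nothing available gives a cause for this result.
As far as these compounds go, whether an amine, a carboxylic acid or a nitrile at this position would move the number beyond the scatter stays open. So does whether the same change would read alike with the pyrrolidin-1-yl group of compound 2.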